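This account rests on a few compounds, and the source may have more. Where it says the series, first, only, none or still open, it means among the compounds named here.

Compound 1 `Nc1ccccc1NC(=O)c1ccc(CSc2ccc(Br)cc2)cc1`: 9.96%
Compound 2 `Nc1ccccc1NC(=O)/C=C/c1ccc(CSc2ccc(F)cc2)cc1`: 14.1%
Compound 3 `Nc1ccccc1NC(=O)/C=C/c1ccc(CSc2cccc(F)c2)cc1`: 7.95%

In a functional assay on HCT-116 cells (Homo sapiens) for inhibition, read by CCK-8 assay, with a stated time of 72 h, tested at 2 uM (a higher number here means more inhibition of growth at the concentration tested, a lower number less inhibition of growth), compound 1 gives 9.96%, the second highest of the three numbers, with compound 3 nearest and compound 2 furthest, yet all three sit within the usual scatter of one another. Compound 4 `Nc1ccccc1NC(=O)c1ccc(CSc2ccc(Cl)cc2)cc1` differs from compound 1 in one place: chloro in place of bromo on an aromatic carbon. Among the measured compounds shown here, no measured step exchanges one halogen for another. For the measured compounds named here, the only measured step, a number 6.2 percentage points lower from compound 2 to compound 3 (within the scatter), swaps 4-fluorophenyl for 3-fluorophenyl on a core that differs from that of compound 1, and it stays within the scatter. With so little bearing on it, no step beyond the scatter is expected. Compound 4 is therefore estimated at 10%, ranging from 2% to 20%. That estimate amounts to an expected step of a number 0 percentage points higher from compound 1 to compound 4 (within the scatter).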

Compound 4, percent growth inhibition at one concentration: 17.5%
Beside the measured number, compound 4's estimate is 7.5 percentage points below it; the range from low to high includes it.
By their numbers in this assay, from the lowest: compounds 3, 1, 2 and 4 (each within the scatter of the next).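

Among the compounds shown here, this is the first measured exchange of one halogen for another at this position: in this assay the change gives a number 7.5 percentage points higher from compound 1 to compound 4 (within the scatter) and so does not separate chloro from bromo on the shared core. No measurement shown bears on the size of this step.
From the compounds shown here alone, whether a methoxy group or an amine in this place would give a step beyond the scatter stays open. So does whether fluoro on the core of compound 1 would read any differently from chloro or bromo.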